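The compounds below may be only part of what the source reports. "The series", "measured", "known", "first", "only" and "open" are said of these compounds alone.

Working notes on the series. For the measured compounds named here, in a functional assay on the whole organism with Rattus norvegicus as the target, at a dose of 25 mg/kg by the intravenous route (on this read-out higher numbers stand for an effect only at larger amounts of compound and lower numbers for an effect already at smaller amounts), compound 1 (`O=C(Nc1ccccc1)c1ccc(-c2nn[nH]n2)cc1`) gives 8.4 mg/kg and compound 2 (`N#Cc1ccc(NC(=O)c2ccc(-c3nn[nH]n3)cc2)cc1`) gives 1.2 mg/kg, the lower of the two numbers so far. The next compound is compound 3 (`NC(=O)c1ccc(NC(=O)c2ccc(-c3nn[nH]n3)cc2)cc1`), with carbamoyl in place of cyano on an aromatic carbon, para to a large group: carbamoyl in place of cyano on an aromatic carbon. Going by the values given here, the only measured step that bears on this change is a 7.0-fold lower number from compound 1 to compound 2 (0.85 log units; beyond the scatter), made at the same place, cyano in place of hydrogen. That step does not exchange these two groups, so it gives only a rough guide to size. A smaller step than that one is expected in this assay, more likely towards a higher number than a lower one. For compound 3 the expected value is 3 mg/kg, with an estimated range of 1 mg/kg to 9 mg/kg. The estimated step is a 2.5-fold higher number from compound 2 to compound 3 (0.40 log units; beyond the scatter).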

Compound 3, dose for 50% inhibition: 2 mg/kg
For compound 3 the middle estimate is 1.5-fold (0.18 log units) above the measured one; low and high end bracket the measured number.
By their numbers in this assay, from the lowest: compounds 2 and 3 (each within the scatter of the next); then compound 1.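

In this assay, carbamoyl in place of cyano on this aromatic carbon, para to a large group, gives a 1.7-fold higher number from compound 2 to compound 3 (0.22 log units; within the scatter), so the two groups cannot be separated on this read-out, although carbamoyl brings a hydrogen-bond donor that cyano lacks. Set against hydrogen, carbamoyl gives a 4.2-fold lower number from compound 1 to compound 3 (0.62 log units; beyond the scatter), so a step beyond the scatter at this position is no longer tied to cyano alone. Nothing measured here explains why these two groups read alike.

Still open, as far as these compounds go, is whether a carboxylic acid or an amine at this position would also stay within the scatter of compound 2 and compound 3. Also open, from the compounds shown here alone, is whether an N-methyl carbamoyl, or a longer chain ending in carbamoyl, would keep the same read-out.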